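A few compounds are considered here, and "the series" means these few. Any claim that something is new, unique, unknown or untested is made for them only; others in the source may bear on it.

The compounds here share one core and were compared in a functional assay on HeLa cells for agonist activity at 5-hydroxytryptamine receptor 6 (Homo sapiens), read by cAMP accumulation and immunoassay; a lower number here means a smaller maximal response, a higher number a larger maximal response. Compound 1, `O=S(=O)(c1cccc(F)c1)c1cn(C2CCNC2)c2ncccc12`, carries a pyrrolidin-3-yl group and gives 44%. Compound 2, `CN1CCC(n2cc(S(=O)(=O)c3cccc(F)c3)c3cccnc32)C1`, differs from it by a single change, (methyl in place of hydrogen on an amine nitrogen in a ring), and gives 54%; the step of a number 10 percentage points higher from compound 1 to compound 2 (within the scatter) therefore says little on its own. Compound 3, `O=S(=O)(c1cc(Cl)cc(Cl)c1)c1cn(C2CCCNC2)c2ncccc12`, carries a piperidin-3-yl group instead and has other differences from compound 1 as well; how the two cores differ is not broken down here. Compound 3 gives 62%, which lies beyond the scatter relative to compound 1 but within the scatter relative to compound 2.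

Compound 4, `CN1CCCC(n2cc(S(=O)(=O)c3cc(Cl)cc(Cl)c3)c3cccnc32)C1`, has not been measured yet. It differs from compound 3 by methyl in place of hydrogen on an amine nitrogen in a ring. For the measured compounds named here, this is the same kind of change as the one from compound 1 to compound 2, not the same change: there the methyl enters on an amine nitrogen of a five-membered non-aromatic ring with one nitrogen, here on an amine nitrogen of a six-membered non-aromatic ring with one nitrogen. The step from compound 3 to compound 4 is expected to be about a number 5 percentage points higher from compound 3 to compound 4 (within the scatter), a small shift at most, because a number 10 percentage points higher from compound 1 to compound 2 (within the scatter) stayed within the scatter. On that basis compound 4 is estimated to reach 67%, with a likely range from 52% to 82%.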

Compound 4, largest response reached (Emax), in percent of the reference or control that the assay uses: 56%
Compound 4: the middle estimate sits 11 percentage points above what was measured; the range from low to high includes it.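

In this assay, putting a methyl on the amine nitrogen of the six-membered ring gives a number 6 percentage points lower from compound 3 to compound 4 (within the scatter), a step too small to mean much when read alone. Set beside the earlier step, however, it shows that this change does not carry over from one core to the other as a fixed shift, so the result on one of these cores is a poor guide to the result on the other: the same change on two cores in this assay, a number 10 percentage points higher (within the scatter) from compound 1 to compound 2 and a number 6 percentage points lower (within the scatter) from compound 3 to compound 4, 16 percentage points apart, beyond the scatter of two such steps This does not show that the methyl reliably raises the response on one core or lowers it on the other, as each step on its own stays within the scatter, and two pairs are too few to establish a rule for the series.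

The cores of compound 1 and compound 3 differ both in the size of the amine ring and in their halogen atoms, and no pair shown changes only one of these, which leaves open which difference goes with the gap between the steps. From the compounds shown here alone, the amine nitrogen carries only hydrogen or methyl here, so it also remains open how a longer chain such as ethyl, or an amide at that nitrogen, would behave on either core.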